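A few compounds are considered here, and "the series" means these few. Any claim that something is new, unique, unknown or untested is made for them only; others in the source may bear on it.

Measured compounds:
- compound 1, `COc1cccc(OS(=O)(=O)c2ccc(N3CCN(C)C3=O)cc2)c1`, which in a functional assay on HT-29 cells (Homo sapiens) for antiproliferative activity, read by sulforhodamine B assay, with a stated time of 48 h (a higher number here means a weaker inhibitor, a lower number a stronger inhibitor), gives 2500 nM
- compound 2, `CN1CCN(c2ccc(S(=O)(=O)Oc3cccc(F)c3)cc2)C1=O`, which in this assay gives > 100000 nM
- compound 3, `CCCN1CCN(c2ccc(S(=O)(=O)Oc3ccc(OC)cc3)cc2)C1=O`, which in this assay gives 16000 nM

The value for compound 2 is a limit of this assay rather than a number: the limit of > 100000 nM in this assay, at which 1 of the 3 values shown sits. Compound 1 and compound 2 share one core and differ in a single spot, (fluoro in place of methoxy on an aromatic carbon); this change produced an at least 40-fold higher number from compound 1 to compound 2 (1.60 log units; beyond the scatter).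

Compound 3 carries a different core, and the difference between the two cores is not broken down here. Its value stands highest of the two numbers, with compound 1 nearest to it.

Compound 4, `CCCN1CCN(c2ccc(S(=O)(=O)Oc3ccc(F)cc3)cc2)C1=O`, is not yet measured. It differs from compound 3 by fluoro in place of methoxy on an aromatic carbon. This is the same kind of change as that from compound 1 to compound 2, though not in the same surroundings: in compound 1 the methoxy sits meta to a large group, whereas in compound 3 it sits para to a large group, and compound 3 has its own core.

Compound 4 is therefore expected to show a step of a 13-fold higher number from compound 3 to compound 4 (1.10 log units; beyond the scatter) in this assay, a loss of the same direction and roughly the same size as that from compound 1 to compound 2, because of an at least 40-fold higher number from compound 1 to compound 2 (1.60 log units; beyond the scatter). On this basis the estimate for compound 4 in this assay is 200000 nM, between 50000 nM and 1000000 nM.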

Compound 4, half-maximal inhibitory concentration: 23000 nM
Compound 4: middle estimate off by 8.7-fold (0.94 log units), on the high side; measured number outside the range, below it.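

On the core of compound 3, putting fluoro in place of methoxy on the aromatic ring gives a 1.4-fold higher number from compound 3 to compound 4 (0.16 log units; within the scatter), so the large loss seen with the same change on the core of compound 1 does not carry over to this second core: the same change on two cores in this assay, an at least 40-fold higher number (1.60 log units; beyond the scatter) from compound 1 to compound 2 and a 1.4-fold higher number (0.16 log units; within the scatter) from compound 3 to compound 4, at least 27-fold (1.44 log units) apart, beyond the scatter of two such steps

Compound 2 gives > 100000 nM, which is a limit of this assay and not a number.

Among these compounds, what the comparison does not show is the reason the two steps part ways: the two pairs differ in the chain on the core and also in where the group sits on the aromatic ring, and these four compounds cannot separate those two differences, so a single pair of steps says only that this change cannot be assumed to transfer unchanged.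

The compounds shown leave open how the change behaves when the chain on the core is held fixed and only the place on the ring is altered. They also leave open what other groups at this place on the ring, such as a chlorine, a hydroxyl or an amine, or a chain longer than propyl on the core, would give in this assay.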